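Series notes: heterocycle exchange on the chain carbon

The source may hold more compounds than are shown below. What is called first, only, known or untested is meant among the compounds shown, and "the series" means these compounds.

The three measured compounds share one core and differ only in the group carried on a saturated chain carbon bound to an aromatic carbon and a saturated chain carbon: compound 1 `CC(C)C(Nc1nnc[nH]1)c1ccc(-c2ccc3cccc(F)c3c2)[nH]c1=O`, compound 2 `CC(C)C(Cc1nnn[nH]1)c1ccc(-c2ccc3cccc(F)c3c2)[nH]c1=O` and compound 3 `CC(C)C(c1noc(=O)[nH]1)c1ccc(-c2ccc3cccc(F)c3c2)[nH]c1=O`. In a functional assay on CHO cells for antagonist activity at prostaglandin E2 receptor EP3 subtype (Homo sapiens), read by cAMP accumulation (a higher number here means a weaker inhibitor, a lower number a stronger inhibitor), compound 1 gives 185 nM, compound 2 gives 134 nM and compound 3 gives 41 nM, the lowest of the three. The step of a 1.4-fold lower number from compound 1 to compound 2 (0.14 log units; within the scatter) stays within the scatter, whereas a 4.5-fold lower number from compound 1 to compound 3 (0.65 log units; beyond the scatter) and a 3.3-fold lower number from compound 2 to compound 3 (0.51 log units; beyond the scatter) are modest but beyond it.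

Compound 4 `CC(C)C(/C=C1/CCNC1=O)c1ccc(-c2ccc3cccc(F)c3c2)[nH]c1=O` differs from compound 3 by a group of 7 heavy atoms (5 carbon, 1 nitrogen, 1 oxygen; one five-membered non-aromatic ring with 1 hetero atom) in place of a group of 6 heavy atoms (2 carbon, 2 nitrogen, 2 oxygen; one five-membered aromatic ring with 3 hetero atoms), on a saturated chain carbon bound to an aromatic carbon and a saturated chain carbon. Among the measured compounds shown here, no measured step covers this exchange directly; the two that bear on it, a 4.5-fold lower number from compound 1 to compound 3 (0.65 log units; beyond the scatter) and a 3.3-fold lower number from compound 2 to compound 3 (0.51 log units; beyond the scatter), show that swapping one five-membered ring for another at this carbon has moved this assay by modest amounts, and compound 3 already holds the lowest number. A modest rise in this assay is therefore expected for compound 4, a 2.7-fold higher number from compound 3 to compound 4 (0.43 log units; beyond the scatter), with the direction not secure. Compound 4 is estimated at 110 nM in this assay, between 35 nM and 350 nM.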

Compound 4, half-maximal inhibitory concentration: 8.1 nM
For compound 4 the middle estimate is 14-fold (1.13 log units) above the measured one; measured number below the stated range.
By their numbers in this assay, from the lowest: compound 4; then compound 3; then compounds 2 and 1 (each within the scatter of the next).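

In this assay, the saturated chain carbon accepts more than an exchange among five-membered aromatic rings: the group with one five-membered non-aromatic ring with 1 hetero atom gives a 5.1-fold lower number from compound 3 to compound 4 (0.70 log units; beyond the scatter), and the larger 17-fold lower number from compound 2 to compound 4 (1.22 log units; beyond the scatter) and a 23-fold lower number from compound 1 to compound 4 (1.36 log units; beyond the scatter). An aromatic ring at this place is therefore not required for the lowest number in the set, and the entering group reaches it with 1 hydrogen-bond acceptor, against 3 in the group that leaves. No evidence on the origin of this step is available.

The ring, its carbonyl and the double bonds all change together, so the compounds shown do not tell which of them carries the step. Also open, as far as these compounds go, is how a carboxylic acid or an amine on the same chain carbon would compare with compound 4.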